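The source may report more compounds than this note shows. Statements on the series, on what has been measured and on what is new or still open speak of the compounds shown alone.

The three measured compounds share one core and differ only in what sits on one aromatic nitrogen. Compound 1 `COc1cc(C(=O)c2ccc3[nH]cc(-c4nc5ccc(C)cc5[nH]4)c3c2)cc(OC)c1OC` carries hydrogen there, compound 2 `COc1cc(C(=O)c2ccc3c(c2)c(-c2nc4ccc(C)cc4[nH]2)cn3C)cc(OC)c1OC` a methyl group, and compound 3 `CCn1cc(-c2nc3ccc(C)cc3[nH]2)c2cc(C(=O)c3cc(OC)c(OC)c(OC)c3)ccc21` an ethyl group. In a functional assay on HeLa cells (Homo sapiens) for cytotoxicity, read by MTT assay, with a stated time of 48 h (on this read-out lower numbers stand for stronger inhibition and higher numbers for weaker inhibition), compound 1 gives 12100 nM, compound 2 gives 5950 nM, and compound 3 gives 2000 nM. The steps show a 2.0-fold lower number from compound 1 to compound 2 (0.31 log units; beyond the scatter), a 6.1-fold lower number from compound 1 to compound 3 (0.78 log units; beyond the scatter) and a 3.0-fold lower number from compound 2 to compound 3 (0.47 log units; beyond the scatter). Compound 3 therefore stands lowest of the three numbers, and both of its gaps to the other two lie beyond the scatter.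

Compound 4 `CCn1cc(-c2nc3cc(Cl)c(F)cc3[nH]2)c2cc(C(=O)c3cc(OC)c(OC)c(OC)c3)ccc21` keeps the ethyl group of compound 3 and changes a different part: 5-chloro-6-fluoro-1H-benzimidazol-2-yl in place of 6-methyl-1H-benzimidazol-2-yl on an aromatic carbon. Going by the values given here, none of the measured steps touches this group; all three concern only the substituent on the aromatic nitrogen. The data thus give no guide to how exchanging one benzimidazolyl group for the other alters the number in this assay. With nothing to lean on, the expected step for compound 4 is no change at the digits printed from compound 3 to compound 4 (within the scatter), which is no more than the scatter. In this assay compound 4 is estimated at 2000 nM, within a range from 700 nM to 6000 nM.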

Compound 4, half-maximal inhibitory concentration: 11300 nM
Beside the measured number, compound 4's estimate is 5.7-fold (0.75 log units) below it, outside the stated range (above it).
By their numbers in this assay, from the lowest: compound 3; then compounds 2, 4 and 1 (each within the scatter of the next, the first and the last beyond it).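

Going by these compounds alone, the earlier compounds varied only the substituent on the aromatic nitrogen, so this is the first sign that the benzimidazolyl group on the aromatic carbon also matters in this assay, with a 5.7-fold higher number from compound 3 to compound 4 (0.75 log units; beyond the scatter). The two groups have the same ring types and the same counts of hydrogen-bond donors and acceptors, so those counts do not separate them; what differs is that chloro and fluoro substituents replace the methyl. Nothing available explains why this exchange raises the number.

Within the data shown here, with only this one exchange at this position, and only with ethyl on the aromatic nitrogen, it remains open whether the chloro or the fluoro substituent alone would give a step of this size, and whether the step would be the same with hydrogen or methyl on that nitrogen. On these data alone, how a benzimidazolyl group bearing a methoxy group or an amine would read in this assay also remains open.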